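Stability of piperidine-substituted amides in human liver microsomes

This account rests on a few compounds, and the source may have more. Where it says the series, first, only, none or still open, it means among the compounds named here.

Measured so far:
Compound 1 `CCCCCOC(=O)N1CCN(C(=O)[C@H](CCC(=O)O)NC(=O)c2cc(N3CCC(COC)CC3)nc(-c3ccccc3)n2)CC1`: > 80%
Compound 2 `CCCCCOC(=O)N1CCN(C(=O)[C@H](CCC(=O)O)NC(=O)c2cc(N3CCC(CNC)CC3)nc(-c3ccccc3)n2)CC1`: > 80%

In an ADME assay on microsomes from liver (Homo sapiens) for metabolic stability (on this read-out higher numbers stand for a more stable compound and lower numbers for a less stable compound), compound 1 reaches only a limit of the assay, > 80%. Compound 2 also reaches only a limit in this assay, > 80%. The step that the two limits leave unreadable from compound 1 to compound 2 therefore cannot be read, because the limit of > 80% in this assay, at which 2 of the 2 values shown sit, holds both values shown.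

Compound 3 `CCCCCOC(=O)N1CCN(C(=O)[C@H](CCC(=O)O)NC(=O)c2cc(N3CCC(C(N)=O)CC3)nc(-c3ccccc3)n2)CC1` is not yet measured. It differs from compound 2 by carbamoyl in place of (methylamino)methyl on a saturated ring carbon. Among the measured compounds shown here, the only measured step, that from compound 1 to compound 2, bears on this change only in part and is itself unreadable, so no size of step in this assay can be derived from it. Given that compound 2 sits at the limit, compound 3 is expected to remain near that limit as well, which means an estimated step that the limit leaves unreadable from compound 2 to compound 3. Compound 3 is estimated at 85%, with a range from 65% to 98%.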

Compound 3, percent of the compound remaining: > 80%
Compound 3 ended at the assay's limit; the forecaster's own chance of this, stated with the estimate: 65%; the middle value does not contradict the limit.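

No step among compound 1, compound 2 and compound 3 can be read in this assay, because all three stand at one limit of the assay: the limit of > 80% in this assay, at which 3 of the 3 values shown sit.

The compounds shown leave open whether methoxymethyl, (methylamino)methyl and carbamoyl differ at all on this read-out.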